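A few compounds are considered here, and "the series" means these few. Any claim that something is new, unique, unknown or untested is made for them only; others in the source may bear on it.

Of the compounds shown here, three from this series have already been measured in a functional assay on SK-OV-3 cells (Homo sapiens) for antiproliferative activity, read by sulforhodamine B assay, with a stated time of 72 h; on this read-out lower numbers stand for stronger inhibition and higher numbers for weaker inhibition. Compound 1, with the structure `O=C1CS/C(=N/Nc2nncc3ccccc23)N1c1ccccc1`, gives 7.9 nM in this assay. Compound 2, `C(=C/c1ccccc1)\C(=N\Nc1nncc2ccccc12)c1ccccc1`, gives 0.01 nM, and compound 3, `N#Cc1ccc(Nc2nncc3ccccc23)cc1`, gives 0.02 nM. Going by the values given here, of the three numbers, the one for compound 1 is the highest, which on this read-out means the weakest inhibition of cell growth; its distance to compound 3 and to compound 2 lies beyond the usual scatter in both cases.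

Compound 4, `CCN1C(=O)CS/C1=N/Nc1nncc2ccccc12`, has not yet been measured in this assay. It keeps the shared core of compound 1 and differs in one place: ethyl in place of phenyl on an amide-type nitrogen in a ring. Among the compounds with values here, no pair of measured compounds differs in exactly this way, so there is no measured step to lean on. The expectation for compound 4 is therefore a modest shift, most likely toward a higher number than compound 1, but one that could well fall within the scatter, giving an expected step of a 1.9-fold higher number from compound 1 to compound 4 (0.28 log units; within the scatter). The estimate for compound 4 in this assay is 15 nM, with a range from 3 nM to 80 nM.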

Compound 4, half-maximal inhibitory concentration: 0.9 nM
The estimate for compound 4 lay 17-fold (1.22 log units) above the measured number; the whole stated range lies above it.
By their numbers in this assay, from the lowest: compounds 2 and 3 (each within the scatter of the next); then compound 4; then compound 1.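

In this assay, the phenyl on the amide-type nitrogen in the ring is not required for activity: with ethyl in its place, there is an 8.8-fold lower number from compound 1 to compound 4 (0.94 log units; beyond the scatter) and this step lies beyond the usual scatter. Going by these compounds alone, this is the first measured pair that isolates a single change, and it shows that the group at this position can shift the read-out, with the smaller, ring-free ethyl giving the stronger inhibition of the two. Nothing available explains why the number falls, so the step stands as an observation without a known cause. A single step between two groups cannot establish a trend with group size at this position. On these data alone, it remains open how methyl, a longer chain such as butyl, or a chain ending in an amine would behave here.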